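This account rests on a few compounds, and the source may have more. Where it says the series, first, only, none or still open, it means among the compounds named here.

In a functional assay on cardiac atrium for agonist activity at histamine H2 receptor (Cavia porcellus) (on this read-out lower numbers stand for smaller maximal responses and higher numbers for larger maximal responses), compound 1 `N=C(NCCCc1c[nH]cn1)NC(=O)C(c1ccccc1)c1ccccc1` gives 69%, the lower of the two numbers in hand. Compound 2 `N=C(NCCCc1c[nH]cn1)NC(=O)CC(c1ccccc1)c1nccs1` gives 100%, a response that lies beyond the scatter from that of compound 1. Compound 3 `CC(C(=O)NC(=N)NCCCc1c[nH]cn1)c1ccccc1` differs from compound 1 in one place: methyl in place of phenyl on a saturated chain carbon bound to an aromatic carbon and a carbonyl carbon. Going by the values given here, no step between measured compounds bears directly on this change. For compound 3 a modest rise in this assay is expected, a step of a number 9 percentage points higher from compound 1 to compound 3 (within the scatter) that may or may not reach beyond the scatter. Compound 3 is therefore estimated at 78%, with a range from 55% to 100%.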

Compound 3, largest response reached (Emax), in percent of the reference or control that the assay uses: 88%
Compound 3: the middle estimate sits 10 percentage points below what was measured; low and high end bracket the measured number.
By their numbers in this assay, from the lowest: compound 1; then compound 3; then compound 2.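

The change on this saturated chain carbon bound to an aromatic carbon and a carbonyl carbon shows that the maximal response does not depend on the second phenyl: in this assay, methyl in its place gives a number 19 percentage points higher from compound 1 to compound 3 (beyond the scatter). This position therefore responds to the change, and the smaller of the two groups gives the larger response in this single pair. Nothing available explains this step. As far as these compounds go, it remains open how a hydrogen, an ethyl group or a hydroxyl group on this same carbon would read in this assay.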